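A few compounds are considered here, and "the series" means these few. Any claim that something is new, unique, unknown or untested is made for them only; others in the source may bear on it.

In a functional assay on UACC-62 cells (Homo sapiens) for cytotoxicity, read by sulforhodamine B assay, with a stated time of 48 h (on this read-out lower numbers stand for stronger inhibition of growth and higher numbers for weaker inhibition of growth), compound 1, `Cn1cccc1-c1cc(-c2ccc(Br)cc2)[nH]c(=O)c1C#N`, gives 48900 nM, the only number shown. Compound 2, `COc1ccc(-c2cc(-c3cccs3)[nH]c(=O)c2C#N)cc1`, reaches only a limit of this assay at > 100000 nM, the limit described in the limit of > 100000 nM in this assay, at which 1 of the 2 values shown sits. Compound 3, `Cn1cccc1-c1cc(-c2ccc(Br)cc2)n(C(=S)Nc2ccc(F)cc2)c(=O)c1C#N`, still awaits measurement in this assay. It differs from compound 1 by a group of 10 heavy atoms (7 carbon, 1 nitrogen, 1 fluorine, 1 sulfur; one six-membered aromatic ring of carbon only) in place of a hydrogen atom, on an aromatic nitrogen. Among the measured compounds shown here, no measured pair shows what such a change does, so the expected step is a 1.6-fold lower number from compound 1 to compound 3 (0.21 log units; within the scatter), within the usual scatter or only modestly beyond it, in either direction. Compound 3 is therefore expected to give about 30000 nM in this assay, within a range from 8000 nM to 100000 nM.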

Compound 3, concentration for 50% growth inhibition: 72400 nM
The estimate for compound 3 lay 2.4-fold (0.38 log units) below the measured number, and the stated range covers the measured number.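

In this assay the swap of the hydrogen atom on the aromatic nitrogen for this much larger group gives a 1.5-fold higher number from compound 1 to compound 3 (0.17 log units; within the scatter) and so shows that this position can carry a large group with no readable change in growth inhibition. Nothing shown gives a reason for this result.

A single change at this position leaves open whether a small group there, such as methyl or acetyl, would behave the same way. On these data alone, it is also open whether oxygen in place of the sulfur, or another substituent in place of the fluorine, would shift the number.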